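Amine-nitrogen substituent and cytotoxicity in the shared core

The source may hold more compounds than are shown below. What is called first, only, known or untested is meant among the compounds shown, and "the series" means these compounds.

Measured so far:
compound 1 `N#CC1=C(NC(=S)Nc2ccccc2)N(c2ccc(S(N)(=O)=O)cc2)C2=C(C(=O)CCC2)C1c1ccc(Cl)cc1Cl`: 40% in a functional assay on Ehrlich cells (Mus musculus) for cytotoxicity, read by trypan blue exclusion, with a stated time of 2 h, tested at 10 ug/mL; a lower number here means a weaker effect, a higher number a stronger effect of the compound at the concentration tested
compound 2 `N#CC1=C(NC(=O)CCC(=O)O)N(c2ccc(S(N)(=O)=O)cc2)C2=C(C(=O)CCC2)C1c1ccc(Cl)cc1Cl`: 20%

Within the data shown here, compound 2 stands at the lowest of the two numbers; its only neighbour is compound 1, and the step of a number 20 percentage points lower from compound 1 to compound 2 (beyond the scatter) is beyond the scatter. That step replaced a group carrying a six-membered aromatic ring on the amine nitrogen with the (2-carboxyethyl)carbonyl group that compound 2 bears.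

Compound 3 `N#CC1=C(NS(=O)(=O)c2ccc(Br)cc2)N(c2ccc(S(N)(=O)=O)cc2)C2=C(C(=O)CCC2)C1c1ccc(Cl)cc1Cl` is still to be measured in this assay. It differs from compound 2 in one place: (4-bromophenyl)sulfonyl in place of (2-carboxyethyl)carbonyl on an amine nitrogen. The change thus takes the (2-carboxyethyl)carbonyl group away again and puts a group with a six-membered aromatic ring in its place. Among the measured compounds shown here, the one step that bears on this is a number 20 percentage points lower from compound 1 to compound 2 (beyond the scatter), which ran in the opposite sense; read backwards it suggests a rise of similar size. On this basis compound 3 is expected to lie above compound 2, at an estimated 40% with a range from 22% to 60%, the expected step being a number 20 percentage points higher from compound 2 to compound 3 (beyond the scatter). A single pair is thin support, so the range is kept wide.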

Compound 3, a percentage reported as activity, at one concentration (the size of the read-out at that concentration, not a potency): 90%
Compound 3: middle estimate off by 50 percentage points, on the low side; measured number above the stated range.
By their numbers in this assay, from the lowest: compound 2; then compound 1; then compound 3.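

In this assay, the (4-bromophenyl)sulfonyl group on the amine nitrogen gives a number 70 percentage points higher from compound 2 to compound 3 (beyond the scatter), the widest gap in the set, and a number 50 percentage points higher from compound 1 to compound 3 (beyond the scatter), so the read-out at this position is far from exhausted by the group on compound 1. Compound 1 and compound 3 both carry a six-membered aromatic ring of carbon only on this nitrogen yet stand well apart, so the presence of that ring does not by itself set the level, and the remaining parts of the two groups count for much of the difference. No accompanying measurement accounts for the size of this rise.

Compound 3 differs from compound 1 in both the link to the nitrogen and the ring substituent, so the shown compounds cannot separate the contribution of the sulfonyl link from that of the bromine. Phenylsulfonyl, 4-chlorophenylsulfonyl, methylsulfonyl or 4-bromobenzoyl on the same nitrogen would pull these apart, and all three numbers come from a single concentration, so potency across the series remains open.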